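Ring swap on a piperazine chain: notes on four compounds

The source may report more compounds than this note shows. Statements on the series, on what has been measured and on what is new or still open speak of the compounds shown alone.

Measured so far in a functional assay on the whole organism for antagonist activity, with Rattus norvegicus as the target; a lower number here means that less compound is needed, a higher number that more compound is needed for the effect:
compound 1 `Clc1cccc2c1CC2CCN1CCN(c2cccc3c2OCCO3)CC1` gives 1.25 mg/kg
compound 2 `Clc1cccc2c1CC2CCCN1CCN(c2cccc3c2OCCO3)CC1` gives 0.63 mg/kg
compound 3 `c1ccc2c(c1)CC(CCN1CCN(c3cccc4c3OCCO4)CC1)C2` gives 0.16 mg/kg

Compound 3 differs from compound 1 by a group of 9 heavy atoms (9 carbon; one five-membered non-aromatic ring of carbon only, one six-membered aromatic ring of carbon only) in place of a group of 9 heavy atoms (8 carbon, 1 chlorine; one four-membered non-aromatic ring of carbon only, one six-membered aromatic ring of carbon only), on a saturated chain carbon, two bonds along the chain from an amine nitrogen in a ring and that change made a step of a 7.8-fold lower number from compound 1 to compound 3 (0.89 log units; beyond the scatter). The values of compound 2 and compound 1 lie within the scatter of each other; how their two cores differ is not broken down here.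

Compound 4 `c1ccc2c(c1)CC(CCCN1CCN(c3cccc4c3OCCO4)CC1)C2` is not yet measured. It differs from compound 2 by a group of 9 heavy atoms (9 carbon; one five-membered non-aromatic ring of carbon only, one six-membered aromatic ring of carbon only) in place of a group of 9 heavy atoms (8 carbon, 1 chlorine; one four-membered non-aromatic ring of carbon only, one six-membered aromatic ring of carbon only), on a saturated chain carbon, three bonds along the chain from an amine nitrogen in a ring. This is the same kind of change as from compound 1 to compound 3, but the place is not identical: there the group sits two bonds along the chain from the amine nitrogen in a ring, here three bonds along. The step from compound 2 to compound 4 is expected to be about a 6.3-fold lower number from compound 2 to compound 4 (0.80 log units; beyond the scatter), resting on the step of a 7.8-fold lower number from compound 1 to compound 3 (0.89 log units; beyond the scatter) in this assay. Compound 4 is thus estimated at 0.1 mg/kg, within 0.04 mg/kg to 0.3 mg/kg.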

Compound 4, minimum effective dose: 0.63 mg/kg
Compound 4: middle estimate off by 6.3-fold (0.80 log units), on the low side, and the stated range ends below it.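

In this assay, the swap to 2,3-dihydro-1H-inden-2-yl gives no change at the digits printed from compound 2 to compound 4 (within the scatter), so the change does not carry over at one size between these two cores: the same change on two cores in this assay, a 7.8-fold lower number (0.89 log units; beyond the scatter) from compound 1 to compound 3 and no change at the digits printed (within the scatter) from compound 2 to compound 4, 7.8-fold (0.89 log units) apart, beyond the scatter of two such steps

The group sits two bonds along the chain from an amine nitrogen in a ring in one pair and three bonds along in the other, but a single pair at each place does not show that this difference alone decides the outcome. Two pairs also set no rule for the wider series.

As far as these compounds go, it remains open how the change behaves with a longer chain. Also open, from the compounds shown here alone, is whether an amine or a carboxylic acid on the 2,3-dihydro-1H-inden-2-yl group would shift the minimum effective dose.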